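Antiproliferative series: chloro added to compound 1

The source may hold more compounds than are shown below. What is called first, only, known or untested is meant among the compounds shown, and "the series" means these compounds.

Measured in a functional assay on U-87MG ATCC cells for antiproliferative activity against U-87 MG (Homo sapiens), read by MTT assay, with a stated time of 48 h, tested at 50 uM; on this read-out higher numbers stand for a weaker effect at the one concentration tested and lower numbers for a stronger effect:
compound 1 `COc1ccc(-c2nc(C)c(C(=O)CSc3nc(-c4ccc(Cl)cc4)c(C#N)c(=O)[nH]3)s2)cc1` gives 48%
compound 2 `Cc1nc(-c2ccccc2)sc1C(=O)CSc1nc(N)c(C#N)c(-c2ccc(Cl)cc2)n1` gives 44.3%
compound 3 `Cc1nc(-c2ccccc2)sc1C(=O)CSc1nc(-c2ccccc2)c(C#N)c(=O)[nH]1` gives 77.5%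

Compound 1 stands second highest of the three numbers in this assay. Its nearest neighbour is compound 2, whose number lies within the usual scatter of it, so no order between these two can be read. Compound 3 lies furthest from compound 1, its number higher by an amount beyond the scatter.

Compound 4 `COc1ccc(-c2nc(C)c(C(=O)CSc3nc(-c4ccc(Cl)c(Cl)c4)c(C#N)c(=O)[nH]3)s2)cc1` is not yet measured. It differs from compound 1 by chloro in place of hydrogen on an aromatic carbon. For the measured compounds named here, no measured pair carries this change, so its size is unknown from the data at hand. The step of a number 3 percentage points lower from compound 1 to compound 4 (within the scatter) is expected to be small, in either direction, or none beyond the scatter. For compound 4 the estimate in this assay is 45%, with a range from 25% to 65%.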

Compound 4, a percentage reported as activity, at one concentration (the size of the read-out at that concentration, not a potency): 78.4%
Compound 4: the middle estimate sits 33.4 percentage points below what was measured; the measured number lies above the stated range.
By their numbers in this assay, from the lowest: compounds 2 and 1 (each within the scatter of the next); then compounds 3 and 4 (each within the scatter of the next).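

In this assay the change from 4-chlorophenyl to 3,4-dichlorophenyl gives a number 30.4 percentage points higher from compound 1 to compound 4 (beyond the scatter) and so a weaker effect at the one concentration tested. For the compounds shown here, as the only measured pair differing in one place, it shows that this aromatic carbon, ortho to a chloro group and meta to a large group, is not neutral to chloro on the core of compound 1. Nothing measured here bears on the reason for this step.

Going by these compounds, whether fluoro, methyl, methoxy or an amine at this carbon would also weaken the effect remains open. So does whether chloro has the same effect on other members of the series.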